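The compounds below may be only part of what the source reports. "The series", "measured", "known", "first", "only" and "open" are said of these compounds alone.

Measured compounds:
compound 1 `Nc1ccccc1NC(=O)c1ccc(CSC(=S)N2CCN(c3ccc(Cl)cc3)CC2)cc1`, 29%
compound 2 `Nc1ccccc1NC(=O)c1ccc(CSC(=S)N2CCc3ccccc32)cc1`, 85.4%
compound 3 `CCN(Cc1ccncc1)C(=S)SCc1ccc(C(=O)Nc2ccccc2N)cc1`, 86.2%

In a functional assay on A-375 cells (Homo sapiens) for antiproliferative activity, read by CCK-8 assay, with a stated time of 72 h, tested at 8 uM (a lower number here means a weaker effect, a higher number a stronger effect of the compound at the concentration tested), compound 1 stands lowest of the three, with compound 2 and compound 3 both well beyond the scatter above it. Compound 4 `Nc1ccccc1NC(=O)c1ccc(CSC(=S)N2CCN(Cc3ccncc3)CC2)cc1` is not yet measured; it differs from compound 1 as follows: (pyridin-4-yl)methyl in place of 4-chlorophenyl on an amine nitrogen in a ring. For the measured compounds named here, the only measured step, a number 0.8 percentage points higher from compound 2 to compound 3 (within the scatter), swaps groups on a thiocarbonyl carbon, not on the ring amine nitrogen, so it bears only loosely on this change, though it shows the (pyridin-4-yl)methyl group present in a strongly acting compound. The step is therefore judged uncertain, with a rise toward the other two compounds plausible but not assured. Compound 4 is expected to give 55%, between 25% and 85%, a step of a number 26 percentage points higher from compound 1 to compound 4 (beyond the scatter).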

Compound 4, a percentage reported as inhibition, at one concentration (the size of the read-out at that concentration, not a potency): 89.5%
Compound 4: the middle estimate sits 34.5 percentage points below what was measured, and the stated range ends below it.
By their numbers in this assay, from the lowest: compound 1; then compounds 2, 3 and 4 (each within the scatter of the next).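

In this assay, the amine nitrogen in the six-membered ring proves a place where the group carried decides the read-out, with a number 60.5 percentage points higher from compound 1 to compound 4 (beyond the scatter). The two groups match in heavy-atom count, so this large step comes with the swap of a ring carbon and chlorine for a ring nitrogen and a methylene link, not with a change in that count. Nothing measured here accounts for the step. The compounds shown leave open whether the ring nitrogen or the methylene link carries the gain, which a benzyl group on that nitrogen would help separate. As far as these compounds go, how a short alkyl chain would read there also remains open.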